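The compounds below may be only part of what the source reports. "The series", "measured", "known", "first", "only" and "open" are said of these compounds alone.

Compound 1 `COc1cccc(/C=N/Nc2ncc3c(n2)n(C2CCCC2)c(=O)c(=O)n3C)c1` anchors this account. In a functional assay on A549 cells (Homo sapiens) for antiproliferative activity, read by MTT assay (on this read-out higher numbers stand for weaker inhibition and lower numbers for stronger inhibition), compound 1 gives 27400 nM, the highest of the three numbers in hand, although the nearest of them lies within the scatter of it. Compound 2 `Cn1c(=O)c(=O)n(C2CCCC2)c2nc(N/N=C/c3cc(C(F)(F)F)c(O)c(C(F)(F)F)c3)ncc21`, with a hydroxy and two trifluoromethyl groups on its aryl ring, gives 22900 nM in this assay. Compound 3 `Cn1c(=O)c(=O)n(C2CCCC2)c2nc(N/N=C/c3cc(C(F)(F)F)cc(C(F)(F)F)c3)ncc21`, the same aryl ring without the hydroxy, gives 3230 nM. Among the compounds with values here, the one single-point step among the measured compounds is a 7.1-fold lower number from compound 2 to compound 3 (0.85 log units; beyond the scatter).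

Compound 4 `Cn1c(=O)c(=O)n(C2CCCC2)c2nc(N/N=C/c3cccc(O)c3)ncc21` is the unmeasured member. It differs from compound 1 by hydrogen in place of methyl on an oxygen on an aromatic ring. Within the data shown here, no measured pair exchanges methoxy for hydroxy, so the only step that bears on this change is the hydroxy-to-hydrogen step above, which moved the number by a modest amount and pointed against the hydroxy. That step sits on a differently substituted aryl ring, and compound 1 already stands at the high end, so the author expects at most a small shift upward, a 1.5-fold higher number from compound 1 to compound 4 (0.16 log units; within the scatter), with a real chance of no change beyond the scatter. The estimate for compound 4 in this assay is 40000 nM, expected between 12000 nM and 130000 nM.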

Compound 4, half-maximal inhibitory concentration: > 100000 nM
Compound 4 gave a limit, no number; the forecaster's own chance of this, stated with the estimate: 25%; middle value at least 2.5-fold (0.39 log units) away from the limit.
By their numbers in this assay, from the lowest: compound 3; then compounds 2 and 1 (each within the scatter of the next). At a limit, above all of these: compound 4.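

In this assay, exchanging methoxy for hydroxy on the aromatic ring of compound 1 is not a silent change: the step is an at least 3.6-fold higher number from compound 1 to compound 4 (0.56 log units; beyond the scatter). Compound 4 gives a limit of the assay and not a number, and it is the only one of the compounds shown to do so: the limit of > 100000 nM in this assay, at which 1 of the 4 values shown sits. Read with a 7.1-fold lower number from compound 2 to compound 3 (0.85 log units; beyond the scatter), this gives a second pair in which the member with the hydroxy carries the higher number, now on a 3-hydroxyphenyl ring with no trifluoromethyl groups, although these two pairs are all that support the pattern.

The limit leaves the full size of the step open, and the compounds shown do not tell whether the same exchange of methoxy for hydroxy would have a similar effect on an aryl ring bearing trifluoromethyl groups. They also leave open how an amine or a longer chain such as ethoxy, in place of the methoxy of compound 1, would read in this assay.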